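The source may report more compounds than this note shows. Statements on the series, on what has been measured and on what is new or still open speak of the compounds shown alone.

Measured so far in a functional assay on SF-295 cells (Homo sapiens) for inhibition, read by colorimetric assay and sulforhodamine B assay, with a stated time of 48 h; a lower number here means a stronger inhibitor of growth, a higher number a weaker inhibitor of growth:
- compound 1 `CCCCCCCCCCCC[C@@H](O)[C@H]1CC[C@H]([C@H](O)CCCCCCCCCCNC(=O)c2ccco2)O1`: 33900 nM
- compound 2 `CCCCCCCCCCCC[C@@H](O)[C@H]1CC[C@H]([C@H](O)CCCCCCCCCCNC(=O)c2ccoc2)O1`: 100000 nM

Compound 2 holds the higher number of this pair in this assay. Compound 3 `CCCCCCCCCCCC[C@@H](O)[C@H]1CC[C@H]([C@H](O)CCCCCCCCCCNC(=O)c2cncs2)O1` carries 1,3-thiazol-5-yl in place of furan-3-yl on a carbonyl carbon, that is, 1,3-thiazol-5-yl in place of furan-3-yl on a carbonyl carbon. Among the measured compounds shown here, one measured step bears on this place: a 2.9-fold higher number from compound 1 to compound 2 (0.47 log units; beyond the scatter), a modest change between the two furan groups. No thiazole result exists yet, so this guide is weak. A modest move towards a lower number is expected, namely a 2.2-fold lower number from compound 2 to compound 3 (0.35 log units; beyond the scatter). The estimate for compound 3 is 45000 nM, with an expected range of 15000 nM to 120000 nM.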

Compound 3, concentration for 50% growth inhibition: 43700 nM
Estimate against measurement, compound 3: 1.0-fold (0.01 log units) above; the range from low to high includes it.
By their numbers in this assay, from the lowest: compounds 1 and 3 (each within the scatter of the next); then compound 2.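

At this place on the carbonyl carbon, 1,3-thiazol-5-yl gives a 2.3-fold lower number from compound 2 to compound 3 (0.36 log units; beyond the scatter) in this assay, so the number for furan-3-yl does not hold for every five-membered aromatic ring here. Against furan-2-yl, the same group gives a 1.3-fold higher number from compound 1 to compound 3 (0.11 log units; within the scatter), so these two rings are not told apart. Nothing shown gives a cause for either step.

Open, as far as these compounds go, is whether a phenyl ring or a carboxylic acid on this carbonyl carbon would leave the span of these three compounds. From the compounds shown here alone, the effect of a longer chain on the amide nitrogen also remains open.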